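The source may hold more compounds than are shown below. What is called first, only, known or untested is meant among the compounds shown, and "the series" means these compounds.

Measured so far in a functional assay on MGC-803 cells (Homo sapiens) for cytotoxicity, read by MTT assay, with a stated time of 72 h; a lower number here means a stronger inhibitor, a higher number a weaker inhibitor:
compound 1 `NC(=O)N1CCN(C(=S)SCc2cn(Cc3ccccc3F)nn2)CC1` gives 11300 nM
compound 2 `CCNC(=O)N1CCN(C(=S)SCc2cn(Cc3ccccc3F)nn2)CC1` gives 2830 nM

Among the compounds with values here, compound 2 stands at the lowest of the two numbers in this assay; its only neighbour is compound 1, and the single measured step, a 4.0-fold lower number from compound 1 to compound 2 (0.60 log units; beyond the scatter), is the whole of what the series shows so far. That step was ethyl in place of hydrogen on an amide-type nitrogen, and it lies beyond the scatter.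

Compound 3 `CC(C)NC(=O)N1CCN(C(=S)SCc2cn(Cc3ccccc3F)nn2)CC1` is the next member. Set against compound 2 the change is methyl in place of hydrogen on a saturated chain carbon bound to an amide-type nitrogen and a saturated chain carbon. Within the data shown here, nothing measured bears on this change directly: the one step known grew the substituent from nothing to ethyl, whereas here the ethyl becomes isopropyl. Among the measured compounds shown here, that step is the only guide, and a further gain of the same size is not assured; the branch is a smaller addition than the first.

On that basis compound 3 is expected to sit near compound 2, with at most a modest move in the lower direction: the step is estimated as a 1.4-fold lower number from compound 2 to compound 3 (0.15 log units; within the scatter). The estimate for compound 3 in this assay is 2000 nM, with a range from 700 nM to 6000 nM.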

Compound 3, half-maximal inhibitory concentration: 1620 nM
Compound 3: middle estimate off by 1.2-fold (0.09 log units), on the high side; the measured number falls inside the stated range.
By their numbers in this assay, from the lowest: compounds 3 and 2 (each within the scatter of the next); then compound 1.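

In this assay, going from ethyl to isopropyl gives a 1.7-fold lower number from compound 2 to compound 3 (0.24 log units; within the scatter), so adding methyl on a saturated chain carbon bound to an amide-type nitrogen and a saturated chain carbon does not separate compound 2 from compound 3 at this level of resolution. The comparison with the unsubstituted parent is clearer: isopropyl in place of hydrogen on the amide-type nitrogen gives a 7.0-fold lower number from compound 1 to compound 3 (0.84 log units; beyond the scatter), so both the ethyl and the isopropyl compounds stand apart from compound 1, while the two alkyl groups cannot be ranked against each other. No supporting measurement accounts for either step.

Still open, on these data alone, is whether a longer chain such as n-butyl, a more heavily branched tert-butyl group or a ring such as cyclohexyl on the same amide-type nitrogen would give a number beyond the scatter of compound 3. Within the data shown here, also open is how a chain ending in a hydroxyl group, an amine or a carboxylic acid would read in this assay, since every substituent at this position so far is hydrogen or a plain alkyl group.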